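Swapping a diketone chain for a methylpyrazole

A few compounds are considered here, and "the series" means these few. Any claim that something is new, unique, unknown or untested is made for them only; others in the source may bear on it.

Measured in a functional assay on DU-145 cells (Homo sapiens) for cytotoxicity, read by MTT assay, with a stated time of 72 h; on this read-out lower numbers stand for stronger inhibition and higher numbers for weaker inhibition:
- Compound 1 `COc1ccc(/C=C/c2cc(C)n[nH]2)cc1`: 8400 nM
- Compound 2 `COc1ccc(/C=C/c2cc(C)no2)cc1OC`: > 100000 nM, a limit of the assay
- Compound 3 `COc1ccc(/C=C/C(=O)CC(C)=O)cc1OC`: 8200 nM

Compound 3 gives 8200 nM and compound 1 gives 8400 nM, so these two numbers lie within the usual scatter of each other. Compound 2 has no exact number, only the limit > 100000 nM.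

Compound 4 `COc1ccc(/C=C/c2cc(C)n[nH]2)cc1OC` keeps the core of compound 3 and changes one group, with 3-methyl-1H-pyrazol-5-yl in place of (2-oxopropyl)carbonyl on a double-bonded chain carbon bound to a double-bonded chain carbon.

Going by the values given here, one measured step touches this place: an at least 12-fold lower number from compound 2 to compound 3 (1.08 log units; beyond the scatter). It is large and beyond the scatter, so the group here can matter a great deal in this assay, at least for that pair. However, it involves a different ring from the one in compound 4. Compound 4 shares its 3-methyl-1H-pyrazol-5-yl group with a closer guide, compound 1, which differs elsewhere and gives 8400 nM. On that basis, no step beyond the scatter is expected in this assay.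

The expected change is a 1.2-fold lower number from compound 3 to compound 4 (0.07 log units; within the scatter). For compound 4 the estimated value is 7000 nM, with an expected range from 2500 nM to 25000 nM.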

Compound 4, half-maximal inhibitory concentration: 18500 nM
Compound 4: the middle estimate sits 2.6-fold (0.42 log units) below what was measured; low and high end bracket the measured number.
By their numbers in this assay, from the lowest: compounds 3 and 1 (each within the scatter of the next); then compound 4. At a limit, above all of these: compound 2.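

In this assay, 3-methyl-1H-pyrazol-5-yl does not act as a like-for-like replacement for (2-oxopropyl)carbonyl on a double-bonded chain carbon bound to a double-bonded chain carbon: the swap gives a 2.3-fold higher number from compound 3 to compound 4 (0.35 log units; beyond the scatter), a modest loss of strength. The result also shows that the aromatic ring carrying the methoxy groups affects the number, since methoxy in place of hydrogen on an aromatic carbon gives a 2.2-fold higher number from compound 1 to compound 4 (0.34 log units; beyond the scatter), so compound 1 was not a fully reliable guide to compound 4. Among the two five-membered rings, 3-methyl-1H-pyrazol-5-yl in place of 3-methyl-1,2-oxazol-5-yl gives an at least 5.4-fold lower number from compound 2 to compound 4 (0.73 log units; beyond the scatter), a step whose full size stays unknown, as compound 2 stands at a limit: the limit of > 100000 nM in this assay, at which 1 of the 4 values shown sits.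

The compounds shown leave open whether methoxy in place of hydrogen on an aromatic carbon would give a similar step when (2-oxopropyl)carbonyl sits on the chain. They also leave open how a carboxylic acid or a primary amide on the same chain carbon would compare with the two groups that give the lower numbers here.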